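Swapping a benzyl group for a sulfur-bearing saturated ring

The source may hold more compounds than are shown below. What is called first, only, known or untested is meant among the compounds shown, and "the series" means these compounds.

Compound 1 `c1ccc(CNCCCCN(C[C@H]2Cc3ccccc3CN2)[C@H]2CCCc3cccnc32)cc1` is the most potent of the three compounds measured in a functional assay on cells for antagonist activity at C-X-C chemokine receptor type 4 (Homo sapiens), read by fluorescence and calcium flux, with stated times of 25 min and 90 s (on this read-out lower numbers stand for stronger inhibition and higher numbers for weaker inhibition), where compound 1 gives 20.1 nM. Two relatives carry a saturated ring in place of the benzyl group: compound 2 `c1ccc2c(c1)CN[C@@H](CN(CCCCNCC1CCOCC1)[C@H]1CCCc3cccnc31)C2` gives 52.9 nM in this assay, and compound 3 `c1ccc2c(c1)CN[C@@H](CN(CCCCNC1CCSCC1)[C@H]1CCCc3cccnc31)C2` gives 54.7 nM. Both changes cost potency, a 2.6-fold higher number from compound 1 to compound 2 (0.42 log units; beyond the scatter) and a 2.7-fold higher number from compound 1 to compound 3 (0.43 log units; beyond the scatter), while the two saturated rings are indistinguishable from one another, a 1.0-fold higher number from compound 2 to compound 3 (0.01 log units; within the scatter).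

Compound 4 `O=S1(=O)CCC(NCCCCN(C[C@H]2Cc3ccccc3CN2)[C@H]2CCCc3cccnc32)CC1` has not yet been measured. Relative to compound 1 the change is 1,1-dioxothian-4-yl in place of benzyl on an amine nitrogen. Among the measured compounds shown here, the nearest precedent is compound 3, whose thian-4-yl ring is the closest relative of the 1,1-dioxothian-4-yl ring of compound 4. Because a 2.7-fold higher number from compound 1 to compound 3 (0.43 log units; beyond the scatter) was a modest loss, a loss of similar or slightly larger size is expected, a 3.5-fold higher number from compound 1 to compound 4 (0.54 log units; beyond the scatter). The estimate for compound 4 in this assay is therefore 70 nM, with a range from 30 nM to 200 nM.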

Compound 4, half-maximal inhibitory concentration: 45.5 nM
For compound 4 the middle estimate is 1.5-fold (0.19 log units) above the measured one; measured number inside the range.
By their numbers in this assay, from the lowest: compound 1; then compounds 4, 2 and 3 (each within the scatter of the next).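

In this assay, the 1,1-dioxothian-4-yl ring, which brings hydrogen-bond acceptors that benzyl lacks, still does not match benzyl on this amine nitrogen (a 2.3-fold higher number from compound 1 to compound 4 (0.35 log units; beyond the scatter)). Among the saturated groups, the new ring cannot be told apart from the thian-4-yl ring (a 1.2-fold lower number from compound 3 to compound 4 (0.08 log units; within the scatter)) or from the (oxan-4-yl)methyl group (a 1.2-fold lower number from compound 2 to compound 4 (0.07 log units; within the scatter)), so in these compounds, changing the ring atom and adding the two oxygens on sulfur leaves the number in the same band, with no compound going against this. No measurement offered here explains why benzyl stands apart from these three groups.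

Going by these compounds, whether a pyridin-4-ylmethyl group or a 4-fluorobenzyl group would keep the level of benzyl remains open. So does the result for a piperidin-4-yl ring, which has an amine in the ring in place of the sulfur.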